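Nitrile to fluoro on the shared core

The source may report more compounds than this note shows. Statements on the series, on what has been measured and on what is new or still open speak of the compounds shown alone.

Measured in a physicochemical assay for lipophilicity, using the shake flask method; a higher number here means a more lipophilic compound, a lower number a more polar compound:
- compound 1 `C[C@H](Oc1cc2cc(C(N)=O)ccc2nc1N)c1cc(F)c(F)cc1-n1cccn1`: 3.2
- compound 2 `C[C@H](Oc1cc2cc(C#N)ccc2nc1N)c1cc(F)c(F)cc1-n1cccn1`: 4.3

Compound 2 stands highest of the two measured compounds, with compound 1 well under it. Compound 3 `C[C@H](Oc1cc2cc(F)ccc2nc1N)c1cc(F)c(F)cc1-n1cccn1` has fluoro in place of cyano on an aromatic carbon. Among the compounds with values here, the only measured step bearing on this is a number 1.10 log units higher from compound 1 to compound 2 (beyond the scatter), a large one. It involves cyano but not fluoro, so it is a weak guide. A smaller upward change in this assay is expected, and the expected step is a number 0.40 log units higher from compound 2 to compound 3 (beyond the scatter). The estimate for compound 3 is 4.7, with an expected range of 4.3 to 5.1.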

Compound 3, distribution coefficient: 4.1
Compound 3: middle estimate off by 0.60 log units, on the high side; measured number below the stated range.
By their numbers in this assay, from the lowest: compound 1; then compounds 3 and 2 (each within the scatter of the next).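

In this assay, fluoro and cyano on this aromatic carbon give numbers that cannot be told apart (a number 0.20 log units lower from compound 2 to compound 3 (within the scatter)). Carbamoyl alone separates from the other two here, as fluoro also stands clear of it (a number 0.90 log units higher from compound 1 to compound 3 (beyond the scatter)), matching the earlier cyano step (a number 1.10 log units higher from compound 1 to compound 2 (beyond the scatter)). No measurement on hand accounts for this.

From the compounds shown here alone, it stays open whether an amine or a carboxylic acid on this carbon would group with carbamoyl or with fluoro and cyano. Going by these compounds, whether the same grouping holds on any other core also stays open.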